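Adding a thiophene ester to compound 2

This account rests on a few compounds, and the source may have more. Where it says the series, first, only, none or still open, it means among the compounds named here.

Values in an ADME assay on HepG2 2.2.15 cells (Homo sapiens) for cytotoxicity, read by MTT assay; on this read-out higher numbers stand for lower toxicity in this test and lower numbers for higher toxicity in this test:
- compound 1 `C=C1CC[C@@H]2[C@](C)(COC(=O)c3cccs3)[C@H](OC(=O)c3cccs3)CC[C@@]2(C)[C@@H]1/C=C/C1=CCOC1=O`: > 1530000 nM
- compound 2 `C=C1CC[C@@H]2[C@](C)(CO)[C@H](OC(=O)c3cccs3)CC[C@@]2(C)[C@@H]1C/C=C1\C=COC1=O`: 257000 nM

The value for compound 1 is a limit of the assay, not a number. Going by the values given here, that leaves compound 2, at 257000 nM, as the only compound with a true number.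

The next step leads to compound 3 `C=C1CC[C@@H]2[C@](C)(COC(=O)c3cccs3)[C@H](OC(=O)c3cccs3)CC[C@@]2(C)[C@@H]1C/C=C1\C=COC1=O`, with hydroxymethyl going to (((thiophen-2-yl)carbonyl)oxy)methyl: (thiophen-2-yl)carbonyl in place of hydrogen on an oxygen on a saturated carbon. Among the compounds with values here, no measured step shows what this change does, so the expectation is tentative. It leans on compound 1, whose value of > 1530000 nM is a limit. A moderate rise in this assay is expected, meaning lower toxicity in this test, and the estimated step is a 2.1-fold higher number from compound 2 to compound 3 (0.33 log units; beyond the scatter). For compound 3 the expected value is 550000 nM, with an estimated range of 170000 nM to 1600000 nM.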

Compound 3, half-maximal cytotoxic concentration: 1370000 nM
Beside the measured number, compound 3's estimate is 2.5-fold (0.40 log units) below it; low and high end bracket the measured number.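

In this assay, going by these compounds alone, replacing the hydrogen on the oxygen of the hydroxymethyl group with (thiophen-2-yl)carbonyl gives a modest step, a 5.3-fold higher number from compound 2 to compound 3 (0.73 log units; beyond the scatter), the first measured step at this position, and it runs towards lower toxicity in this test. The change therefore has a readable size on this pair, which compound 2 alone could not show. The other step, an at least 1.1-fold lower number from compound 1 to compound 3 (0.04 log units; that floor lies within the scatter), is only a floor. Compound 1 stands at a limit of the assay: the limit of > 1530000 nM in this assay, at which 1 of the 3 values shown sits.

The compounds shown leave open whether this rise is particular to the thiophene ring or would also follow from an acetyl or benzoyl ester on the same oxygen. They also leave open what an amine or a carboxylic acid in place of the hydroxy would do in this assay.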